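The compounds below may be only part of what the source reports. "The series", "measured", "known", "first", "only" and "open" are said of these compounds alone.

Compound 1, `COC(=O)CCNC(=O)Cn1cc(C2=C(c3c[nH]c4ccccc34)C(=O)N(C)C2=O)c2ccccc21`, gives 44500 nM in a functional assay on A2780 cells (Homo sapiens) for cytotoxicity, read by MTT assay, with a stated time of 24 h; a lower number here means a stronger inhibitor, a higher number a weaker inhibitor.
Compound 2, `COC(=O)[C@@H](C)NC(=O)Cn1cc(C2=C(c3c[nH]c4ccccc34)C(=O)N(C)C2=O)c2ccccc21`, gives 15800 nM in this assay.
Compound 3, `COC(=O)C[C@@H](NC(=O)Cn1cc(C2=C(c3c[nH]c4ccccc34)C(=O)N(C)C2=O)c2ccccc21)C(=O)OC`, gives 15400 nM in this assay.

Compound 2 stands second highest of these three numbers; compound 3 is its nearest neighbour, a 1.0-fold lower number from compound 2 to compound 3 (0.01 log units; within the scatter), while compound 1 lies furthest off, a 2.8-fold lower number from compound 1 to compound 2 (0.45 log units; beyond the scatter). Compound 4, `COC(=O)[C@@H](CO)NC(=O)Cn1cc(C2=C(c3c[nH]c4ccccc34)C(=O)N(C)C2=O)c2ccccc21`, differs from compound 2 by hydroxy in place of hydrogen on a saturated chain carbon, two bonds along the chain from an amide-type nitrogen and a carbonyl carbon. The step that bears most directly on this is the one in which methoxycarbonyl enters at the same place and the number hardly moves: a 1.0-fold lower number from compound 2 to compound 3 (0.01 log units; within the scatter). The remaining step, a 2.9-fold lower number from compound 1 to compound 3 (0.46 log units; beyond the scatter), was modest and involved a different place. The expectation is therefore a step within the scatter, a 1.1-fold lower number from compound 2 to compound 4 (0.02 log units; within the scatter). Compound 4 is estimated at 15000 nM, with a range from 6000 nM to 40000 nM.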

Compound 4, half-maximal inhibitory concentration: 23200 nM
Beside the measured number, compound 4's estimate is 1.5-fold (0.19 log units) below it; low and high end bracket the measured number.
By their numbers in this assay, from the lowest: compounds 3, 2, 4 and 1 (each within the scatter of the next, the first and the last beyond it).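

With a hydroxy group on this saturated chain carbon, the step is again within the scatter in this assay: a 1.5-fold higher number from compound 2 to compound 4 (0.17 log units; within the scatter). Exchanging methoxycarbonyl for hydroxy at the same place also stays within it, with a 1.5-fold higher number from compound 3 to compound 4 (0.18 log units; within the scatter), so neither group separates itself from the other or from the methyl of compound 2. Compound 4 also remains within the scatter of compound 1, with a 1.9-fold lower number from compound 1 to compound 4 (0.28 log units; within the scatter), and no measurement here accounts for these steps.

Going by these compounds, whether an amine, a carboxylic acid or a longer chain at this carbon would give a step beyond the scatter remains open.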